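The source may hold more compounds than are shown below. What is called first, only, known or untested is meant among the compounds shown, and "the series" means these compounds.

In a functional assay on MCF7 cells (Homo sapiens) for antiproliferative activity (a higher number here means a weaker inhibitor, a lower number a stronger inhibitor), compound 3 `C=CCc1cc(C(=O)Nc2cc3ccc(OC4CCN(C)CC4)c(C)c3oc2=O)ccc1O` gives 2170 nM. That is level within the scatter with compound 2 `CC(=O)Oc1ccc(C(=O)Nc2cc3ccc(OC4CCN(C)CC4)c(C)c3oc2=O)cc1Cl` at 1610 nM and with compound 1 `Cc1c(OC2CCN(C)CC2)ccc2cc(NC(=O)c3ccc(O)c(CCC(C)C)c3)c(=O)oc12` at 1250 nM. Compound 4 `Cc1c(OC2CCN(C)CC2)ccc2cc(NC(=O)c3ccc(O)c(Cl)c3)c(=O)oc12` has chloro in place of allyl on an aromatic carbon, ortho to a hydroxy group: chloro in place of allyl on an aromatic carbon. For the measured compounds named here, two measured steps bear on this. One is a 1.7-fold higher number from compound 1 to compound 3 (0.24 log units; within the scatter), with vinyl in place of isobutyl. The other is a 1.3-fold higher number from compound 2 to compound 3 (0.13 log units; within the scatter), with 3-allyl-4-hydroxyphenyl in place of 4-acetoxy-3-chlorophenyl. Neither exceeds the scatter, so no step beyond the scatter is expected in this assay. The expected change is a 1.3-fold lower number from compound 3 to compound 4 (0.11 log units; within the scatter). Compound 4 is estimated at 1700 nM, with an expected range of 800 nM to 3600 nM.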

Compound 4, half-maximal inhibitory concentration: 1480 nM
For compound 4 the middle estimate is 1.1-fold (0.06 log units) above the measured one; low and high end bracket the measured number.
By their numbers in this assay, from the lowest: compounds 1, 4, 2 and 3 (each within the scatter of the next).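

In this assay this position, ortho to a hydroxy group, takes chloro as readily as a carbon chain: chloro in place of allyl gives a 1.5-fold lower number from compound 3 to compound 4 (0.17 log units; within the scatter) and chloro in place of isopentyl gives a 1.2-fold higher number from compound 1 to compound 4 (0.07 log units; within the scatter) in the same assay. With chloro kept, hydrogen in place of acetyl on the oxygen gives a 1.1-fold lower number from compound 2 to compound 4 (0.04 log units; within the scatter) and so separates the free hydroxy from the acetoxy form by no more than the scatter. No evidence at hand accounts for these steps.

As far as these compounds go, whether an amine or a carboxylic acid at this position would give a step beyond the scatter stays open. So does the outcome of a methyl ether on the oxygen.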